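The compounds below may be only part of what the source reports. "The series", "measured", "known", "first", "only" and "open" are said of these compounds alone.

Measured in a functional assay on HL-60 cells (Homo sapiens) for antiproliferative activity, with a stated time of 72 h; a lower number here means a stronger inhibitor, a higher number a weaker inhibitor:
- compound 1 `OC[C@H]1O[C@@H](n2cnc3c(NCc4ccccc4F)ncnc32)[C@H](O)[C@@H]1O`: 3200 nM
- compound 2 `OC[C@H]1O[C@@H](n2cnc3c(NCc4ccc(Cl)cc4)ncnc32)[C@H](O)[C@@H]1O`: 1700 nM
- compound 3 `COc1cccc(CNc2ncnc3c2ncn3[C@@H]2O[C@H](CO)[C@@H](O)[C@H]2O)c1`: 4900 nM

Compound 3 cannot be told apart from its nearest neighbour, with a 1.5-fold higher number from compound 1 to compound 3 (0.19 log units; within the scatter). Its gap to the remaining compound is wider, with a 2.9-fold higher number from compound 2 to compound 3 (0.46 log units; beyond the scatter).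

Compound 4 `COc1cccc(CNc2ncnc3c2ncn3[C@@H]2O[C@H](CO)[C@@H](O)[C@H]2O)c1OC` carries methoxy in place of hydrogen on an aromatic carbon, ortho to a large group and ortho to a methoxy group, which turns 3-methoxyphenyl into 2,3-dimethoxyphenyl (methoxy in place of hydrogen on an aromatic carbon).

Within the data shown here, no measured step adds a group in this way. The nearest evidence comes from swaps of one substituted phenyl for another, and these stay small: a 1.9-fold lower number from compound 1 to compound 2 (0.27 log units; within the scatter), alongside the two steps above. Even the largest of them is only modest. No step beyond the scatter is therefore expected in this assay, and no direction is favoured with any confidence. The expected change is a 1.1-fold lower number from compound 3 to compound 4 (0.04 log units; within the scatter). For compound 4 the estimated value is 4500 nM, with an expected range from 1800 nM to 11000 nM.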

Compound 4, half-maximal inhibitory concentration: > 166000 nM
Compound 4: a limit, no number (the forecaster's own chance of this, stated with the estimate: 10%); middle value at least 36-fold (1.56 log units) from the limit.
By their numbers in this assay, from the lowest: compounds 2, 1 and 3 (each within the scatter of the next, the first and the last beyond it). At a limit, above all of these: compound 4.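

In this assay the result for compound 4 is a limit, not a number: the limit of > 166000 nM in this assay, at which 1 of the 4 values shown sits.

The aromatic carbon ortho to a large group and ortho to a methoxy group proves sensitive in a way the earlier swaps of one substituted phenyl for another did not reveal: this single methoxy in place of hydrogen gives an at least 33-fold higher number from compound 3 to compound 4 (1.52 log units; beyond the scatter), a far larger step than any among the first three compounds. The 2,3-dimethoxyphenyl group stands equally far from the other two aryl groups, with an at least 97-fold higher number from compound 2 to compound 4 (1.98 log units; beyond the scatter) and with an at least 51-fold higher number from compound 1 to compound 4 (1.71 log units; beyond the scatter).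

The compounds shown leave open whether 2-methoxyphenyl, without the second methoxy, would behave like 2,3-dimethoxyphenyl. They also leave open how a hydroxy or an amine on this same carbon would fare.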